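Carboxy replaces phenyl on the chain of compound 3

The compounds below may be only part of what the source reports. "The series", "measured", "known", "first", "only" and "open" are said of these compounds alone.

Measured in an ADME assay on HOS cells (Homo sapiens) for cytotoxicity, read by luminescence and ATP content, with a stated time of 48 h; a higher number here means that more compound is tolerated, a lower number that less compound is tolerated:
- Compound 1 `O=C(NCc1ccc(F)cc1F)c1c(O)c2cc(CCCCCO)cnc2n(O)c1=O`: > 250000 nM, a limit of the assay
- Compound 2 `Nc1c(C(=O)NCc2ccc(F)cc2F)c(=O)n(O)c2ncc(CCCC3CCCCC3)cc12`: 27400 nM
- Compound 3 `Nc1c(C(=O)NCc2ccc(F)cc2F)c(=O)n(O)c2ncc(CCc3ccccc3)cc12`: 18000 nM

Compound 3 stands within the scatter of compound 2, as a 1.5-fold lower number from compound 2 to compound 3 (0.18 log units; within the scatter) shows. Compound 4 `Nc1c(C(=O)NCc2ccc(F)cc2F)c(=O)n(O)c2ncc(CCC(=O)O)cc12` carries carboxy in place of phenyl on a saturated chain carbon, two bonds along the chain from an aromatic carbon. That single measured step exchanges one ring for another, so it bears only weakly on this change. Compound 1, which has no ring on its chain but differs in other ways too, stands at the limit of > 250000 nM in this assay, at which 1 of the 3 values shown sits. On that loose guide, a higher number is expected in this assay. The estimated step is a 5.0-fold higher number from compound 3 to compound 4 (0.70 log units; beyond the scatter). For compound 4 the estimated value is 90000 nM, with an expected range of 30000 nM to 250000 nM.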

Compound 4, half-maximal cytotoxic concentration: > 250000 nM
Compound 4 gave a limit, no number (the forecaster's own chance of this, stated with the estimate: 25%); at least 2.7-fold (0.44 log units) between middle value and limit.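

In this assay, for the compounds shown here, the earlier compounds showed only that phenyl and cyclohexylmethyl at this place stand within the scatter of each other, whereas carboxy shows that a change here can move the number well beyond it. The change gives an at least 13-fold higher number from compound 3 to compound 4 (1.14 log units; beyond the scatter), and also an at least 9.1-fold higher number from compound 2 to compound 4 (0.96 log units; beyond the scatter). Compound 4 gives a limit rather than a number, so both steps are minimum sizes: the limit of > 250000 nM in this assay, at which 2 of the 4 values shown sit.

As far as these compounds go, how far compound 4 lies past that limit remains open. So does whether an amine, or a longer chain ending in carboxy, would behave the same way.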